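A Benzyl Sulfone Variant of Compound 2

The compounds below may be only part of what the source reports. "The series", "measured", "known", "first", "only" and "open" are said of these compounds alone.

Compound 2 `COc1ccccc1/C=C(\C(=O)c1ccc(Cl)cc1)S(=O)(=O)c1ccc(C)cc1` gives 1000 nM in a functional assay on DU-145 cells (Homo sapiens) for inhibition, read by trypan blue exclusion, with a stated time of 96 h; a higher number here means a weaker inhibitor of growth, a lower number a stronger inhibitor of growth. Compound 3 `Cc1ccc(S(=O)(=O)/C(=C/c2cc(C)cc(C)c2)C(=O)c2ccc(Cl)cc2)cc1` gives 1000 nM; the step of no change at the digits printed from compound 2 to compound 3 (within the scatter) leaves the two level, together the lowest pair of the three. Compound 1 `Cc1ccc(S(=O)(=O)/C(=C/c2ccccc2F)C(=O)c2ccc(Cl)cc2)cc1` gives 2500 nM, and both a 2.5-fold lower number from compound 1 to compound 2 (0.40 log units; beyond the scatter) and a 2.5-fold lower number from compound 1 to compound 3 (0.40 log units; beyond the scatter) are modest. Compound 4 `COc1ccccc1/C=C(\C(=O)c1ccc(Cl)cc1)S(=O)(=O)Cc1ccc(C)cc1` differs from compound 2 in one place: 4-methylbenzyl in place of 4-methylphenyl on a sulfonyl sulfur. Every measured step changes the aromatic ring on the double-bonded chain carbon and none touches the group on the sulfonyl sulfur, so the data give no direct guide for this change. The expected step of a 1.5-fold higher number from compound 2 to compound 4 (0.18 log units; within the scatter) is therefore small, in either direction. Compound 4 is estimated to give 1500 nM, with a range from 500 nM to 4500 nM.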

Compound 4, concentration for 50% growth inhibition: 10000 nM
The estimate for compound 4 lay 6.7-fold (0.82 log units) below the measured number, outside the stated range (above it).
By their numbers in this assay, from the lowest: compounds 2 and 3 (each within the scatter of the next); then compound 1; then compound 4.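

At the sulfonyl sulfur, this assay responds strongly: 4-methylbenzyl in place of 4-methylphenyl gives a 10-fold higher number from compound 2 to compound 4 (1.00 log units; beyond the scatter) and this step is larger than any among compounds 1, 2 and 3. The two groups share one six-membered aromatic ring and differ by one carbon, so a small change at this place can weaken growth inhibition clearly. Nothing available explains this loss.

From the compounds shown here alone, whether a longer chain such as 2-phenylethyl on the sulfonyl sulfur would raise the number further remains open. So does whether the same change would act alike with the 3,5-dimethylphenyl of compound 3.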